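The source may hold more compounds than are shown below. What is called first, only, known or untested is meant among the compounds shown, and "the series" means these compounds.

Measured in a functional assay on HT-29 cells (Homo sapiens) for cytotoxicity, read by MTT assay, with a stated time of 48 h; on this read-out lower numbers stand for stronger inhibition and higher numbers for weaker inhibition:
- compound 1 `CCn1c(=O)ccn(C2OC(Cn3cc(COC(=O)CNC(=O)Cn4cnc5c4c(=O)n(C)c(=O)n5C)nn3)C(OC)C2OC)c1=O`: 74300 nM
- compound 2 `Cn1c(=O)c2c(ncn2CC(=O)OCCc2cn(CC3OC(n4ccc(=O)[nH]c4=O)C4OC(C)(C)OC34)nn2)n(C)c1=O`: 100000 nM
- compound 3 `C#CCNC(=O)Cn1cnc2c1c(=O)n(C)c(=O)n2C`: 19400 nM

Compound 3 has the lowest number of the three, and its gaps to compound 1 and compound 2 both lie beyond the scatter. Compound 4 `C#CCOC(=O)Cn1cnc2c1c(=O)n(C)c(=O)n2C` keeps the shared core of compound 3 and carries one change, propargyloxy in place of propargylamino on a carbonyl carbon. Within the data shown here, no measured pair isolates this change, so the expectation rests on the structural change alone. No step beyond the scatter is expected in this assay, and no direction is favoured. The estimated step runs a 1.0-fold higher number from compound 3 to compound 4 (0.01 log units; within the scatter). For compound 4 the expected value is 20000 nM, with an estimated range of 8000 nM to 55000 nM.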

Compound 4, half-maximal inhibitory concentration: 68300 nM
For compound 4 the middle estimate is 3.4-fold (0.53 log units) below the measured one; the whole stated range lies below it.
By their numbers in this assay, from the lowest: compound 3; then compounds 4, 1 and 2 (each within the scatter of the next).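

Among these compounds, on the carbonyl carbon whose other neighbour is a saturated chain carbon, propargyloxy in place of propargylamino is the first single change that can be read, and in this assay it gives a 3.5-fold higher number from compound 3 to compound 4 (0.55 log units; beyond the scatter) which lies beyond the scatter. The atom linking the propargyl group to the carbonyl therefore matters here, with the amide form holding the lower number. Nothing available accounts for this step.

The compounds shown do not separate the amide hydrogen from the rest of the change. A methyl-substituted amide nitrogen would test this, and a longer alkynyl chain would show whether the step persists.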